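The source may hold more compounds than are shown below. What is called first, only, known or untested is meant among the compounds shown, and "the series" means these compounds.

In an assay on isolated protein with Bile acid receptor (Homo sapiens) as the target (a lower number here means that less compound is needed, a higher number that more compound is needed for the effect), three compounds built on one shared core have been measured. Compound 1 `COC(=O)/C=C/c1cccc(N(Cc2ccccc2)C(=O)C2CCCCC2)c1` gives > 1000 nM, which is a limit of the assay rather than a number (the limit of > 1000 nM in this assay, at which 1 of the 3 values shown sits). Compound 2 `COC/C=C/c1ccc(CN(C(=O)C2CCCCC2)c2cccc(/C=C/C(=O)OC)c2)cc1` gives 233 nM. Compound 3 `COC(=O)/C=C/c1cccc(N(Cc2ccc(-c3ccc(SC)cc3)cc2)C(=O)C2CCCCC2)c1` gives 69 nM, the lowest of the two numbers, with compound 2 nearest to it; the step of a 3.4-fold lower number from compound 2 to compound 3 (0.53 log units; beyond the scatter) is modest, while an at least 14-fold lower number from compound 1 to compound 3 (1.16 log units; beyond the scatter) is large.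

Compound 4 `COC(=O)/C=C/c1cccc(N(Cc2ccc(-c3cc(Cl)ccc3OC)cc2)C(=O)C2CCCCC2)c1` has not yet been measured. It differs from compound 3 in a single place: 5-chloro-2-methoxyphenyl in place of 4-(methylsulfanyl)phenyl on an aromatic carbon. Within the data shown here, the steps that bear on this place are an at least 14-fold lower number from compound 1 to compound 3 (1.16 log units; beyond the scatter) and a 3.4-fold lower number from compound 2 to compound 3 (0.53 log units; beyond the scatter), both of which show that placing an aromatic ring there gives a lower number than hydrogen or than 3-methoxyprop-1-en-1-yl. Compound 4 keeps an aromatic ring at that place, only with a different substitution, so the step of a 1.4-fold higher number from compound 3 to compound 4 (0.16 log units; within the scatter) is expected to stay within the usual scatter. Compound 4 is therefore estimated to give 100 nM, most likely between 30 nM and 350 nM.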

Compound 4, half-maximal effective concentration: 233 nM
For compound 4 the middle estimate is 2.3-fold (0.37 log units) below the measured one, and the stated range covers the measured number.
By their numbers in this assay, from the lowest: compound 3; then compounds 2 and 4 (each within the scatter of the next). At a limit, above all of these: compound 1.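

Among these compounds, a ring at this place does not settle the number by itself: with a 3.4-fold higher number from compound 3 to compound 4 (0.53 log units; beyond the scatter), the substituents on the added ring clearly matter, which the earlier compounds could not show. The ring also no longer gives a lower number than the open chain in every case, since no change at the digits printed from compound 2 to compound 4 (within the scatter) leaves 5-chloro-2-methoxyphenyl and 3-methoxyprop-1-en-1-yl indistinguishable here, whereas 4-(methylsulfanyl)phenyl did give a lower number than that chain. Hydrogen still compares poorly, with an at least 4.2-fold lower number from compound 1 to compound 4 (0.63 log units; beyond the scatter), but that step starts from a limit for compound 1, not from a number: the limit of > 1000 nM in this assay, at which 1 of the 4 values shown sits.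

From the compounds shown here alone, the two rings differ in methylsulfanyl, chloro and methoxy groups at once, and which of these matters most stays open. Also open, going by these compounds, is how a plain phenyl, or a phenyl carrying an amine or a carboxylic acid, would compare with compound 3.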